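Nitro for Cyano on a Tetrazole-Bearing Thiazolylidene Hydrazide

The compounds below may be only part of what the source reports. "The series", "measured", "known", "first", "only" and "open" are said of these compounds alone.

Of the compounds shown here, two have been tested in an ADME assay on NIH3T3 cells (Mus musculus) for cytotoxicity, read by MTT assay, with a stated time of 24 h; a higher number here means a weaker inhibitor, a lower number a stronger inhibitor. Compound 1 `Cn1cnnc1SCC(=O)N/N=c1/scc(-c2ccc([N+](=O)[O-])cc2)n1-c1ccccc1` gives 133 ug/mL in this assay. Compound 2 `Cn1nnnc1SCC(=O)N/N=c1/scc(-c2ccc(C#N)cc2)n1-c1ccccc1` gives 213 ug/mL in this assay, the higher of the two numbers, yet its gap to compound 1 lies within the usual scatter, so the two readings show no difference that can be trusted. Compound 3 `Cn1nnnc1SCC(=O)N/N=c1/scc(-c2ccc([N+](=O)[O-])cc2)n1-c1ccccc1` has not yet been measured in this assay. It differs from compound 2 in one place: nitro in place of cyano on an aromatic carbon. Within the data shown here, no step between two measured compounds covers this change alone, since compound 1 and compound 2 also differ in the ring carrying the methyl group. With only these two values to lean on, and with compound 1 at 133 ug/mL already carrying the nitro group, the account expects compound 3 to land close to its neighbours, with a step from compound 2 of a 1.3-fold lower number from compound 2 to compound 3 (0.11 log units; within the scatter), in size no more than the scatter and in no firm direction. The estimate for compound 3 in this assay is 165 ug/mL, with a range from 90 ug/mL to 300 ug/mL.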

Compound 3, half-maximal inhibitory concentration: 167 ug/mL
Compound 3: the middle estimate sits 1.0-fold (0.01 log units) below what was measured, and the stated range covers the measured number.
By their numbers in this assay, from the lowest: compounds 1, 3 and 2 (each within the scatter of the next).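

Among these compounds, compound 3 supplies the first comparisons that change one place at a time. In this assay, replacing cyano with nitro on the aromatic carbon para to a large group gives a 1.3-fold lower number from compound 2 to compound 3 (0.11 log units; within the scatter) and so does not separate 4-cyanophenyl from 4-nitrophenyl at this position, at least with the 1-methyl-1H-tetrazol-5-yl group on the sulfur. The change on the sulfur, 1-methyl-1H-tetrazol-5-yl in place of 4-methyl-4H-1,2,4-triazol-3-yl with the 4-nitrophenyl group held constant, gives a 1.3-fold higher number from compound 1 to compound 3 (0.10 log units; within the scatter) and is likewise unresolved, so neither change read alone yields a difference that can be trusted, and the three compounds together show no preference in this assay for either group at either place.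

Still open, on these data alone, is whether a group of another kind at the same aromatic carbon, such as an amine or a carboxylic acid, or a longer alkyl chain on the sulfur in place of either ring, would move the number beyond the scatter. Nothing else in hand bears on these readings or offers an account of them.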